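The compounds below may be only part of what the source reports. "The series", "measured", "known", "first", "only" and "open" are said of these compounds alone.

Compound 1 `CCOC(=O)c1csc2nc(CN3CCN(C)CC3)c(-c3ccc(OC)cc3)n12` is the reference point; in a functional assay on HepG2 cells (Homo sapiens) for antiproliferative activity, read by MTT assay, with a stated time of 72 h (a higher number here means a weaker inhibitor, a lower number a stronger inhibitor), compound 1 gives 68400 nM. Compound 2 `CCOC(=O)c1csc2nc(CN3CCN(C)CC3)c(-c3ccc(Br)cc3)n12` carries the change bromo in place of methoxy on an aromatic carbon on the same core, and in this assay compound 2 gives 82700 nM; the step is a 1.2-fold higher number from compound 1 to compound 2 (0.08 log units; within the scatter). Compound 3 `COc1ccc(-c2c(CN3CCCCC3)nc3scc(C(=O)O)n23)cc1` has a different core, and the difference between the two cores is not broken down here; in this assay compound 3 gives 75100 nM, within the scatter of compound 1 and compound 2. Going by the values given here, compound 4 `O=C(O)c1csc2nc(CN3CCCCC3)c(-c3ccc(Br)cc3)n12` is not yet measured; from compound 3 it carries bromo in place of methoxy on an aromatic carbon, the same change as the one from compound 1 to compound 2. Among the compounds with values here, the expected step is a 1.2-fold higher number from compound 3 to compound 4 (0.08 log units; within the scatter), resting on a 1.2-fold higher number from compound 1 to compound 2 (0.08 log units; within the scatter) as the only precedent. For compound 4 the estimate is 90000 nM, with a range from 45000 nM to 180000 nM.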

Compound 4, half-maximal inhibitory concentration: > 100000 nM
Compound 4: a limit, no number (the forecaster's own chance of this, stated with the estimate: 15%); middle value at least 1.1-fold (0.04 log units) from the limit.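

In this assay compound 4 gives > 100000 nM, which is a limit of the assay and not a number. Bromo in place of methoxy therefore yields an at least 1.3-fold higher number from compound 3 to compound 4 (0.12 log units; that floor lies within the scatter), a floor that fixes no size for the step. The change from 4-methoxyphenyl to 4-bromophenyl can be called neither the same nor different on the two cores, and two pairs show no general rule for the series: the same change on two cores in this assay, a 1.2-fold higher number (0.08 log units; within the scatter) from compound 1 to compound 2 and an at least 1.3-fold higher number (0.12 log units; that floor lies within the scatter) from compound 3 to compound 4; the limit leaves it open whether they differ

The two cores differ at both the ethyl ester or carboxylic acid and the amine side chain, and these compounds do not separate the two places. Also open, on these data alone, is how groups such as fluoro, an amine or a primary amide would read in place of bromo on the aromatic ring.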